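This account rests on a few compounds, and the source may have more. Where it says the series, first, only, none or still open, it means among the compounds named here.

Measured compounds in the series:

compound 1 `COc1cc(-c2nn(-c3cccc(NC(=O)c4cccc(C(F)(F)F)c4)c3)cc2-c2ccncc2)ccc1Cl` — > 50000 nM
compound 2 `O=C(Nc1cccc(-n2cc(-c3ccncc3)c(-c3ccc(Cl)c(O)c3)n2)c1)Nc1cc(C(F)(F)F)cc(C(F)(F)F)c1` — 5790 nM

Compound 1 reaches only a limit in a functional assay on MCF7 cells (Homo sapiens) for inhibition, read by sulforhodamine B assay, with a stated time of 48 h (a higher number here means a weaker inhibitor of growth, a lower number a stronger inhibitor of growth), namely > 50000 nM, so no number is known for it. That is the limit of > 50000 nM in this assay, at which 1 of the 2 values shown sits. Compound 2 gives a number in this assay, 5790 nM; it differs from compound 1 in more than one place, so the two values are merely set side by side here and no single change accounts for the difference.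

Compound 3 `COc1cc(-c2nn(-c3cccc(NC(=O)c4ccccc4)c3)cc2-c2ccncc2)ccc1Cl` is not yet measured. Compared with compound 1 the change is hydrogen in place of trifluoromethyl on an aromatic carbon. Within the data shown here, no measured pair shows what this change alone does, so the direction and size of the step are open. Starting from a limit, the expectation for compound 3 is that it stays at or near that limit: the expected step that the limit leaves unreadable from compound 1 to compound 3 is small, none beyond the usual scatter in either direction. Compound 3 is therefore estimated at 60000 nM in this assay, with a range from 20000 nM to 200000 nM, and a real chance that the measurement again reports only a limit.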

Compound 3, concentration for total growth inhibition: > 100000 nM
Compound 3: no number, only a limit; the forecaster's own chance of this, stated with the estimate: 65%; middle value at least 1.6-fold (0.22 log units) from the limit.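

Compound 3 gives only a limit (> 100000 nM) in this assay. Among these compounds, compound 1 also gives only a limit (> 50000 nM), so no step between compound 1 and compound 3 can be read. As far as these compounds go, what hydrogen in place of trifluoromethyl on an aromatic carbon does to growth inhibition remains open, as neither compound has a number.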